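The source may report more compounds than this note shows. Statements on the series, on what has been measured and on what is new or still open speak of the compounds shown alone.

Compound 1 `COc1cc(-c2nnc3n2NC(c2ccco2)C(C(=O)c2ccccc2C)S3)cc(OC)c1OC` gives 80000 nM in a functional assay on A549 cells (Homo sapiens) for cytotoxicity, read by MTT assay, with a stated time of 48 h (a lower number here means a stronger inhibitor, a higher number a weaker inhibitor), the lower of the two plain numbers in hand, though compound 3 `COc1cc(-c2nnc3n2NC(c2ccco2)C(C(=O)c2ccc(F)c(F)c2)S3)cc(OC)c1OC` lies within the scatter of it at 93700 nM. Compound 2 `COc1cc(-c2nnc3n2NC(c2ccco2)C(C(=O)c2cccc4ccccc24)S3)cc(OC)c1OC` reaches only a limit in this assay, > 100000 nM. Compound 4 `COc1cc(-c2nnc3n2NC(c2ccco2)C(C(=O)c2ccc(C(F)(F)F)cc2)S3)cc(OC)c1OC` differs from compound 1 at one place: 4-(trifluoromethyl)phenyl in place of 2-methylphenyl on a carbonyl carbon. Going by the values given here, two measured steps touch the same carbonyl carbon, an at least 1.2-fold higher number from compound 1 to compound 2 (0.09 log units; that floor lies within the scatter) and a 1.2-fold higher number from compound 1 to compound 3 (0.07 log units; within the scatter); neither moved the number beyond the scatter, and the limit of > 100000 nM in this assay, at which 1 of the 3 values shown sits, marks where compound 2 ended. The account therefore expects no step beyond the scatter for the change to compound 4, the expected step being a 1.1-fold higher number from compound 1 to compound 4 (0.03 log units; within the scatter). For compound 4 the estimate in this assay is 85000 nM, with a range from 45000 nM to 160000 nM.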

Compound 4, half-maximal inhibitory concentration: 37200 nM
Beside the measured number, compound 4's estimate is 2.3-fold (0.36 log units) above it, and the stated range ends above it.
By their numbers in this assay, from the lowest: compound 4; then compounds 1 and 3 (each within the scatter of the next). At a limit, above all of these: compound 2.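

In this assay the place on the carbonyl carbon proves able to move the number, with a 2.2-fold lower number from compound 1 to compound 4 (0.33 log units; beyond the scatter) and a 2.5-fold lower number from compound 3 to compound 4 (0.40 log units; beyond the scatter) as steps beyond the scatter, which the earlier changes there did not give. The step of an at least 2.6-fold lower number from compound 2 to compound 4 (0.42 log units; beyond the scatter) also lies beyond the scatter, but it is only a floor. Compound 2 stands at a limit: the limit of > 100000 nM in this assay, at which 1 of the 4 values shown sits. From the compounds shown here alone, whether the lower number belongs to the trifluoromethyl group as such stays open. So does what a nitrile, an amine or a carboxylic acid on the phenyl ring would give.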